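Adding a Nitro Group to Compound 2

The source may report more compounds than this note shows. Statements on the series, on what has been measured and on what is new or still open speak of the compounds shown alone.

Two compounds have been measured in an ADME assay on CCRF-CEM cells (Homo sapiens) for cytotoxicity, with a stated time of 72 h; a lower number here means a stronger inhibitor, a higher number a weaker inhibitor:

Compound 1, `Cc1ccc(-c2nc3sc(Cc4ccc(Cl)cc4)nn3c2C=O)cc1`: 17000 nM
Compound 2, `O=Cc1c(-c2ccccc2)nc2sc(Cc3ccc(Cl)cc3)nn12`: 22000 nM

Compound 2 has the higher of the two numbers, but the step of a 1.3-fold higher number from compound 1 to compound 2 (0.11 log units; within the scatter) lies within the scatter, so the two compounds cannot be told apart on these measurements. Compound 3, `O=Cc1c(-c2ccc([N+](=O)[O-])cc2)nc2sc(Cc3ccc(Cl)cc3)nn12`, differs from compound 2 by nitro in place of hydrogen on an aromatic carbon. Among the compounds with values here, no measured step involves a nitro group, or any group at this place other than hydrogen and methyl; the only measured step, a 1.3-fold higher number from compound 1 to compound 2 (0.11 log units; within the scatter), concerns a methyl and was within the scatter, so it offers no direction for the present change. With nothing in the data pointing either way, the expectation is a step no larger than the scatter, a 1.1-fold lower number from compound 2 to compound 3 (0.04 log units; within the scatter), with a wide uncertainty. For compound 3 the estimate is 20000 nM, expected to fall between 6000 nM and 65000 nM.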

Compound 3, half-maximal inhibitory concentration: 13000 nM
Estimate against measurement, compound 3: 1.5-fold (0.19 log units) above; measured number inside the range.
By their numbers in this assay, from the lowest: compounds 3, 1 and 2 (each within the scatter of the next).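

In this assay, this place on the aromatic ring now carries a third group, and the change to nitro gives a 1.7-fold lower number from compound 2 to compound 3 (0.23 log units; within the scatter), while the swap of methyl for nitro gives a 1.3-fold lower number from compound 1 to compound 3 (0.12 log units; within the scatter). The earlier pair showed only that a single methyl could be exchanged for hydrogen within the scatter; these steps show the same for nitro, a larger group of 3 heavy atoms with 2 hydrogen-bond acceptors, so hydrogen, methyl and nitro cannot be told apart here. No available evidence explains why the three numbers lie so close together.

Still open, going by these compounds, is whether any group at this place can move the number beyond the scatter, such as an amine, a carboxylic acid or a longer chain. Also open, on these data alone, is whether these three groups would still match if the aldehyde were replaced by an amide.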